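The source may hold more compounds than are shown below. What is called first, only, known or untested is meant among the compounds shown, and "the series" means these compounds.

Measured compounds:
- compound 1, `CC(C)(C)N(NC(=O)c1ccccc1)C(=O)c1ccccc1I`, 105 nM
- compound 2, `CC(C)(C)N(NC(=O)c1ccccc1F)C(=O)c1ccccc1Cl`, 51.3 nM
- compound 3, `CC(C)(C)N(NC(=O)c1cccc(Br)c1)C(=O)c1ccccc1Cl`, 191 nM

These three compounds were tested in an assay on cells for agonist activity at ecdysone receptor (Bombyx mori), read by a luciferase reporter, with a stated time of 24 h; a higher number here means that more compound is needed for the effect, a lower number that less compound is needed. Compound 2 has the lowest number of the three: compound 1 sits higher than compound 2, and compound 3 sits higher still, the latter gap being described by a 3.7-fold higher number from compound 2 to compound 3 (0.57 log units; beyond the scatter), a modest step that goes beyond the scatter.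

The unmeasured compound 4, `CC(C)(C)N(NC(=O)c1ccc(F)cc1)C(=O)c1ccccc1Cl`, is obtained from compound 2 by the change (4-fluorophenyl in place of 2-fluorophenyl on a carbonyl carbon). Going by the values given here, the only step among the measured compounds that bears on this position is the one from compound 2 to compound 3, which moved the substituent on the same ring and raised the number modestly. The present change is smaller in kind, swapping one fluorophenyl for another, so little movement beyond the scatter is expected. For compound 4 in this assay the expected value is 60 nM, with a range from 20 nM to 180 nM, meaning an expected step of a 1.2-fold higher number from compound 2 to compound 4 (0.07 log units; within the scatter).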

Compound 4, half-maximal effective concentration: 389 nM
Beside the measured number, compound 4's estimate is 6.5-fold (0.81 log units) below it, and the stated range ends below it.
By their numbers in this assay, from the lowest: compound 2; then compounds 1 and 3 (each within the scatter of the next); then compound 4.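

Moving the fluorine on this ring, with the same atoms kept, gives a 7.6-fold higher number from compound 2 to compound 4 (0.88 log units; beyond the scatter) in this assay, so the place of the halogen counts by itself here; the earlier compounds could not show this, since compound 3 differs from compound 2 in both the halogen and its place. The 4-fluorophenyl group also gives a higher number than the 3-bromophenyl group, with a 2.0-fold higher number from compound 3 to compound 4 (0.31 log units; beyond the scatter), although that pair again changes both the halogen and its place. Nothing at hand gives a reason for either step.

Still open, as far as these compounds go, is whether a methoxy group or an amine in place of the fluorine on this ring would follow the same order. Also open, from the compounds shown here alone, is whether the effect of moving the fluorine holds when the iodophenyl group of compound 1 replaces the other ring.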